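Removing the Methyl from the Indole Amide

A few compounds are considered here, and "the series" means these few. Any claim that something is new, unique, unknown or untested is made for them only; others in the source may bear on it.

Measured compounds:
Compound 1, `CC(=O)Nc1nc2ccc(NC(=O)c3cc(Br)c(Br)[nH]3)cc2s1` — > 50000 nM
Compound 2, `CCOC(=O)C(=O)Nc1nc2ccc(NC(=O)c3ccccc3)cc2s1` — 9730 nM
Compound 3, `CCOC(=O)C(=O)Nc1ccc2nc(NC(=O)c3cc4cc(C)ccc4[nH]3)sc2c1` — 2810 nM

All three were tested in a functional assay on SK-BR-3 cells (Homo sapiens) for antiproliferative activity; a lower number here means that less compound is needed, a higher number that more compound is needed for the effect. Compound 1 gives > 50000 nM, which is not a number but a limit of the assay; its value is the limit of > 50000 nM in this assay, at which 1 of the 3 values shown sits. Compound 2 gives 9730 nM. Compound 3 gives 2810 nM, the lowest of the two numbers shown, and its gap to compound 2 lies beyond the usual scatter of repeated measurements. Compound 3 thus stands as the most potent of the numbered pair.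

Compound 4, `CCOC(=O)C(=O)Nc1ccc2nc(NC(=O)c3cc4ccccc4[nH]3)sc2c1`, differs from compound 3 in one place: hydrogen in place of methyl on an aromatic carbon. Both compounds share the same core and the same amide linkage; only the small alkyl group on the outer ring is lost.

Among the measured compounds shown here, no two measured compounds differ in exactly this way, so the size of the step cannot be read from the data. Such a small change is expected to move the number only a little, if at all, most likely toward a slightly higher value. Compound 4 is therefore estimated at 4000 nM, with a range from 1500 nM to 12000 nM. This corresponds to an expected step of a 1.4-fold higher number from compound 3 to compound 4 (0.15 log units; within the scatter), which may well fall within the scatter.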

Compound 4, half-maximal effective concentration: 5410 nM
Compound 4: the middle estimate sits 1.4-fold (0.13 log units) below what was measured, within the range that was stated.
By their numbers in this assay, from the lowest: compounds 3, 4 and 2 (each within the scatter of the next, the first and the last beyond it). At a limit, above all of these: compound 1.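

In this assay, among the compounds shown here, replacing the 5-methyl-1H-indol-2-yl group with 1H-indol-2-yl gives a 1.9-fold higher number from compound 3 to compound 4 (0.28 log units; within the scatter), and this is the first comparison where two compounds differ in only one place. At this aromatic carbon of the six-membered ring, the methyl therefore makes no difference that this assay can separate from ordinary scatter, and compound 4 still gives a measurable number without it. Nothing measured here offers a reason for this small step.

Only hydrogen and methyl are compared on this carbon, so a chlorine atom, a methoxy group or an amine there could give quite a different number, and one small step says nothing about how such groups would behave. The other end of the molecule is also open, since an ethyl ester is the only group of its kind in compounds 2, 3 and 4, and a carboxylic acid in its place is untested in what is shown; steps between these compounds and the others cannot be read, because each such pair differs in more than one place.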